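The source may report more compounds than this note shows. Statements on the series, on what has been measured and on what is new or still open speak of the compounds shown alone.

In an ADME assay (liver) for metabolic stability, with Liver microsome (Rattus norvegicus) as the target, using microsomes (on this read-out lower numbers stand for slow clearance and higher numbers for fast clearance), compound 2 `CN(C(=O)c1csc(-c2cccnc2)n1)c1ccc(OCc2ccc3ccccc3n2)cc1` gives > 283 mL/min/kg, which is a limit and not a number. Compound 3 `CN(C(=O)c1csc(-c2cccnc2)n1)c1ccc(OCc2ccc3ccccc3c2)cc1` gives > 283 mL/min/kg, also a limit. Among the measured compounds shown here, the one measured step, a step that the two limits leave unreadable from compound 2 to compound 3, has no readable size and so gives no guide to the change followed here. Compound 4 `CN(C(=O)c1cc(-c2ccccn2)n[nH]1)c1ccc(OCc2ccc3ccccc3n2)cc1` keeps the quinolin-2-yl of compound 2 but has 3-(pyridin-2-yl)-1H-pyrazol-5-yl in place of 2-(pyridin-3-yl)-1,3-thiazol-4-yl on a carbonyl carbon. For the measured compounds named here, the only other guide is compound 1 `CN(C(=O)c1cc(-c2ccccn2)[nH]n1)c1ccc(OCB2C=Cc3ccccc3N2)cc1`, which also carries a pyridinyl pyrazole and gives 25 mL/min/kg, although it differs elsewhere too. A clear fall in clearance is therefore expected, namely an at least 3.1-fold lower number from compound 2 to compound 4 (0.49 log units; beyond the scatter). Compound 4 is estimated at 90 mL/min/kg, with an expected range from 30 mL/min/kg to 250 mL/min/kg.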

Compound 4, clearance: 35 mL/min/kg
Beside the measured number, compound 4's estimate is 2.6-fold (0.41 log units) above it; low and high end bracket the measured number.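

In this assay the change to 3-(pyridin-2-yl)-1H-pyrazol-5-yl on a carbonyl carbon gives an at least 8.0-fold lower number from compound 2 to compound 4 (0.90 log units; beyond the scatter) and so provides the first readable size for a change in this series; the step from compound 2 to compound 3 cannot be read, since both values are limits. Going by these compounds, the full size of the new step stays unknown because compound 2 sits at a limit of the assay: the limit of > 283 mL/min/kg in this assay, at which 2 of the 4 values shown sit. Still open, on these data alone, is whether the fall comes from replacing the thiazole with the pyrazole or from moving from pyridin-3-yl to pyridin-2-yl. As far as these compounds go, how a phenyl group in place of the pyridin-2-yl would read is also open.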